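Trading the piperazine for acetoxy on a shared oxazolidinone core

The source may hold more compounds than are shown below. What is called first, only, known or untested is meant among the compounds shown, and "the series" means these compounds.

Measured compounds:
compound 1, `CN1CCN(C[C@H]2CN(c3ccc(-n4cc(-c5ccccn5)cn4)c(F)c3)C(=O)O2)CC1`: 70 ug/mL
compound 2, `CCN1CCN(C[C@H]2CN(c3ccc(-n4cc(-c5ccccn5)cn4)c(F)c3)C(=O)O2)CC1`: 99 ug/mL
compound 3, `COC(=O)CC1CCN(C[C@H]2CN(c3ccc(-n4cc(-c5ccccn5)cn4)c(F)c3)C(=O)O2)CC1`: reported only as the assay limit > 400 ug/mL

In an ADME assay on L02 cells (Homo sapiens) for cytotoxicity, read by MTT assay, with a stated time of 48 h (on this read-out higher numbers stand for weaker inhibition and lower numbers for stronger inhibition), compound 1 gives 70 ug/mL, the lowest of the two plain numbers shown, with compound 2 nearest to it. The move from compound 1 to compound 2 stays within the scatter: a 1.4-fold higher number from compound 1 to compound 2 (0.15 log units; within the scatter). Compound 3 is different in kind, since its read-out is a limit rather than a number, (the limit of > 400 ug/mL in this assay, at which 1 of the 3 values shown sits). The two steps that reach it are both beyond the scatter: an at least 5.7-fold higher number from compound 1 to compound 3 (0.75 log units; beyond the scatter) and an at least 4.0-fold higher number from compound 2 to compound 3 (0.60 log units; beyond the scatter).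

Compound 4, `CC(=O)OC[C@H]1CN(c2ccc(-n3cc(-c4ccccn4)cn3)c(F)c2)C(=O)O1`, follows the step from compound 1 with this change: acetoxy in place of 4-methylpiperazin-1-yl on a saturated chain carbon bound to a saturated ring carbon. Among the compounds with values here, the steps that bear on it are those from compound 1 and compound 2 to compound 3, where the 4-methylpiperazin-1-yl or 4-ethylpiperazin-1-yl group was likewise replaced on a saturated chain carbon bound to a saturated ring carbon, and the number rose by at least a modest amount. The step from compound 1 to compound 2 does not bear on it. Compound 4 is therefore expected to show a higher number than compound 1 in this assay, with a fair chance that only a limit is reported. The estimate for compound 4 is 220 ug/mL, in the range 90 ug/mL to 400 ug/mL, which means an expected step of a 3.1-fold higher number from compound 1 to compound 4 (0.50 log units; beyond the scatter).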

Compound 4, half-maximal inhibitory concentration: > 400 ug/mL
Compound 4 ended at the assay's limit; the forecaster's own chance of this, stated with the estimate: 40%; middle value at least 1.8-fold (0.25 log units) away from the limit.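

In this assay, the group on the saturated chain carbon bound to a saturated ring carbon can now be exchanged for one with no ring at all and the number still rises beyond the scatter, with acetoxy giving an at least 5.7-fold higher number from compound 1 to compound 4 (0.75 log units; beyond the scatter) and an at least 4.0-fold higher number from compound 2 to compound 4 (0.60 log units; beyond the scatter). Until now, the only such rise had come with 4-((methoxycarbonyl)methyl)piperidin-1-yl, which keeps a ring on that carbon, so compound 4 shows that a ring there is not needed for this outcome. The step between compound 3 and compound 4 cannot be read, and both compounds stand at the same limit: the limit of > 400 ug/mL in this assay, at which 2 of the 4 values shown sit.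

The compounds shown leave open how far beyond that limit compound 3 and compound 4 lie, and so which of the two replacements moves the number more. On these data alone, it also remains open what a morpholin-4-yl ring or a simple hydroxyl would give on the same carbon, which would help separate the loss of the 4-methylpiperazin-1-yl group from the arrival of an ester.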